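A few compounds are considered here, and "the series" means these few. Any claim that something is new, unique, unknown or untested is made for them only; others in the source may bear on it.

Measured in an ADME assay on Vero cells (Chlorocebus sabaeus) for cytotoxicity, read by MTT assay, with a stated time of 72 h; a lower number here means that less compound is tolerated, a higher number that more compound is tolerated:
- Compound 1 `CCOC(=O)c1c(-c2ccc(OC)cc2)oc2ccc(OCCCCCN3C(=O)C(=O)c4cc(F)ccc43)cc12`: 512 ug/mL
- Compound 2 `CCOC(=O)c1c(-c2ccc(OC)cc2)oc2ccc(OCCCCCCN3C(=O)/C(=N\OC)c4ccccc43)cc12`: 32 ug/mL

Compound 1 holds the higher of these two numbers, and compound 2 lies below it by a gap beyond the scatter. Compound 3 `CCOC(=O)c1c(-c2ccc(OC)cc2)oc2ccc(OCCCCCCN3C(=O)C(=O)c4ccccc43)cc12` has not yet been measured. It differs from compound 1 as follows: a group of 12 heavy atoms (9 carbon, 1 nitrogen, 2 oxygen; one five-membered non-aromatic ring with 1 hetero atom, one six-membered aromatic ring of carbon only) in place of a group of 12 heavy atoms (8 carbon, 1 nitrogen, 2 oxygen, 1 fluorine; one five-membered non-aromatic ring with 1 hetero atom, one six-membered aromatic ring of carbon only), on a saturated chain carbon, five bonds along the chain from an oxygen on an aromatic ring. Among the measured compounds shown here, no measured pair shows this change on its own, so the size of the step remains uncertain. A downward move is expected, with an estimated 4.0-fold lower number from compound 1 to compound 3 (0.60 log units; beyond the scatter). Compound 1 stands at 512 ug/mL. For the measured compounds named here, that is the higher of only two numbers. For compound 3 the expected value is 128 ug/mL, within an estimated range of 32 ug/mL to 512 ug/mL.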

Compound 3, half-maximal cytotoxic concentration: 256 ug/mL
Compound 3: the middle estimate sits 2.0-fold (0.30 log units) below what was measured, within the range that was stated.
By their numbers in this assay, from the lowest: compound 2; then compounds 3 and 1 (each within the scatter of the next).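

In this assay, replacing the fluorine-bearing group of 12 heavy atoms with the fluorine-free group, on the saturated chain carbon five bonds along the chain from an oxygen on an aromatic ring, gives a 2.0-fold lower number from compound 1 to compound 3 (0.30 log units; within the scatter). This change therefore leaves the read-out within the scatter, so the fluorine-bearing group is not needed here to keep these numbers at this level. The compounds shown do not separate the loss of fluorine from the other differences within the group, and what a longer chain or an amine at this place would give remains open. Nothing available accounts for this result.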